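The source may report more compounds than this note shows. Statements on the series, on what has been measured and on what is new or still open speak of the compounds shown alone.

Among the measured compounds shown here, in an ADME assay on cells (Fibroblast, Homo sapiens) for cytotoxicity, with a stated time of 48 h (on this read-out higher numbers stand for weaker inhibition and lower numbers for stronger inhibition), compound 3 `O=[N+]([O-])c1ccc(CN2CCC(n3cc(CC(OCc4cc(-c5cccc(F)c5)no4)c4ccc(Br)cc4)nn3)CC2)cc1` gives 10000 nM, the only reading in this set that is a number rather than a limit. Compound 1 `O=[N+]([O-])c1ccc(CN2CCC(n3cc(CC(OCc4cc(-c5ccc(F)cc5)no4)c4ccc(Br)cc4)nn3)CC2)cc1` stops at the assay limit of > 25000 nM. Compound 2 `COc1ccc(-c2cc(COC(Cc3cn(C4CCN(Cc5ccc([N+](=O)[O-])cc5)CC4)nn3)c3ccc(Br)cc3)on2)cc1` likewise stops at the limit of > 25000 nM. The steps of an at least 2.5-fold lower number from compound 1 to compound 3 (0.39 log units; beyond the scatter) and an at least 2.5-fold lower number from compound 2 to compound 3 (0.39 log units; beyond the scatter) both start from the limit of > 25000 nM in this assay, at which 2 of the 3 values shown sit. Compound 4 `COc1cccc(-c2cc(COC(Cc3cn(C4CCN(Cc5ccc([N+](=O)[O-])cc5)CC4)nn3)c3ccc(Br)cc3)on2)c1` differs from compound 3 by methoxy in place of fluoro on an aromatic carbon. For the measured compounds named here, the same exchange occurs from compound 1 to compound 2, where a step that the two limits leave unreadable from compound 1 to compound 2, so no measured step reads the size of this change. Compound 4 is therefore expected to shift by a 1.5-fold higher number from compound 3 to compound 4 (0.18 log units; within the scatter), within the scatter. Compound 4 is estimated at 15000 nM, between 5000 nM and 50000 nM.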

Compound 4, half-maximal inhibitory concentration: > 25000 nM
Compound 4: no number, only a limit (the forecaster's own chance of this, stated with the estimate: 35%); middle value at least 1.6-fold (0.22 log units) away from the limit.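

In this assay, methoxy in place of fluoro on this aromatic carbon, meta to a large group, now has a readable size, which the pair of compound 1 and compound 2 could not give: an at least 2.5-fold higher number from compound 3 to compound 4 (0.39 log units; beyond the scatter). The place alone therefore does not yield a numerical reading, as 3-fluorophenyl does in compound 3 but 3-methoxyphenyl does not in compound 4. The steps from compound 1 and from compound 2 to compound 4 cannot be read, because both ends of each sit at one mark: the limit of > 25000 nM in this assay, at which 3 of the 4 values shown sit.

From the compounds shown here alone, how far compound 4 lies beyond compound 3 stays open. So does whether chloro, hydroxyl or an amine at this place would read nearer to compound 3 or to compound 4.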